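The compounds below may be only part of what the source reports. "The series", "measured", "known", "first", "only" and "open" are said of these compounds alone.

Compound 3, `COc1ccc(/C=C/C(=O)c2sc(Nc3ccc(Cl)c(Cl)c3)nc2C)cc1`, was tested in a functional assay on Bel-7402 cells (Homo sapiens) for cytotoxicity, read by MTT assay; on this read-out lower numbers stand for stronger inhibition and higher numbers for weaker inhibition. In this assay compound 3 gives only > 25000 nM, which is a limit of the assay rather than a measured number. Compound 1, `COc1cccc(/C=C/C(=O)c2sc(Nc3cccc(C)c3)nc2C)c1`, shares the core of compound 3. In this assay compound 1 gives > 25000 nM, again a limit. Compound 2, `COc1cccc(/C=C/C(=O)c2sc(Nc3ccc(C)cc3)nc2C)c1`, gives in this assay > 25000 nM, also a limit. For the measured compounds named here, all three measured values therefore sit at the limit of > 25000 nM in this assay, at which 3 of the 3 values shown sit, and the one comparable step, a step that the two limits leave unreadable from compound 1 to compound 2, cannot be read at all. Compound 4, `COc1cccc(/C=C/C(=O)c2sc(Nc3ccc(Cl)c(Cl)c3)nc2C)c1`, is not yet measured; it differs from compound 3 by 3-methoxyphenyl in place of 4-methoxyphenyl on a double-bonded chain carbon bound to a double-bonded chain carbon. Going by the values given here, no measured step covers this particular change; compounds 1 and 2 already carry the 3-methoxyphenyl group on the same side of the molecule and both rest at the limit. The expectation is therefore that the step that the limit leaves unreadable from compound 3 to compound 4 stays within the scatter and that compound 4 also remains at the limit. Compound 4 is estimated at 40000 nM, with a range from 12000 nM to 130000 nM.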

Compound 4, half-maximal inhibitory concentration: > 25000 nM
Compound 4 was reported as a limit; the forecaster's own chance of this, stated with the estimate: 85%; the middle value lies beyond the limit too.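

For the compounds shown here, compound 4 rests at the same limit as compound 1, compound 2 and compound 3, so no step among them can be read in this assay: the limit of > 25000 nM in this assay, at which 4 of the 4 values shown sit. The compounds shown leave open which change to the methoxyphenyl or the group on the nitrogen, if any, would give a readable value in this assay.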